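The compounds below may be only part of what the source reports. "The series", "measured", "known", "first", "only" and "open" are said of these compounds alone.

Compound 2, `COc1ccc(/C=C\c2ccc3c(c2)C(C)(C)CCC3(C)C)cc1`, gives no number in a functional assay on HL-60 cells (Homo sapiens), with a stated time of 48 h; a lower number here means that less compound is needed, a higher number that more compound is needed for the effect: for compound 2 the assay reports only the limit > 100000 nM, so where it stands on the scale is not known beyond that line, and it sits at the limit of > 100000 nM in this assay, at which 1 of the 2 values shown sits. The other measured compound, compound 1, `CC1(C)CCC(C)(C)c2cc(/C=C/c3ccc(N)cc3)ccc21`, gives 38000 nM in this assay, a value that is a number and not a limit.

Compound 3, `CC1(C)CCC(C)(C)c2cc(/C=C\c3ccc(N)cc3)ccc21`, has not been measured. It differs from compound 2 in one place: amino in place of methoxy on an aromatic carbon. Among the measured compounds shown here, no measured pair shows this change, so its size in this assay is not known from the data.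

The expectation is that compound 3 will come in under the limit of compound 2 and give a number, an estimated step of an at least 1.6-fold lower number from compound 2 to compound 3 (0.22 log units; that floor lies within the scatter). Compound 1 also bears the amino group and gives 38000 nM in this assay. Compound 3 is therefore estimated at 60000 nM, with a range from 15000 nM to 200000 nM.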

Compound 3, concentration for half-maximal activity: 38000 nM
Compound 3: the middle estimate sits 1.6-fold (0.20 log units) above what was measured; the range from low to high includes it.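

In this assay, amino in place of methoxy on an aromatic carbon, para to a large group, turns a compound without a number into one with a number, giving an at least 2.6-fold lower number from compound 2 to compound 3 (0.42 log units; beyond the scatter). This step is only a floor, as its starting point at compound 2 is a limit of the assay and not a number: the limit of > 100000 nM in this assay, at which 1 of the 3 values shown sits. With the amino group in place, the configuration of the double bond gives no change at the digits printed from compound 1 to compound 3 (within the scatter), and this reading speaks to that one feature alone because of a single fact: the fact that compounds 1 and 3 differ only in the configuration as drawn.

The compounds shown leave open how large the step from methoxy to amino really is, and whether a hydroxyl, a dimethylamino group or a carboxylic acid in the place of the amino group would give a lower number in this assay. They also leave open whether the configuration of the double bond would matter just as little with a group other than amino in that place.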